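From methoxy to chloro on compound 3

A few compounds are considered here, and "the series" means these few. Any claim that something is new, unique, unknown or untested is made for them only; others in the source may bear on it.

- Compound 1 `Cc1cc(Nc2cc(N3CCN(C)CC3)nc(Nc3ccc(S(N)(=O)=O)cc3)n2)n[nH]1`: 926 nM
- Compound 2 `Cc1cc(Nc2cc(N3CCN(C)CC3)nc(Nc3ccc([N+](=O)[O-])cc3)n2)n[nH]1`: 1200 nM
- Compound 3 `COc1cccc(Nc2nc(Nc3cc(C)[nH]n3)cc(N3CCN(C)CC3)n2)c1`: 2650 nM

In a functional assay on DU-145 cells (Homo sapiens) for antiproliferative activity, read by CCK-8 assay, with a stated time of 72 h (a lower number here means a stronger inhibitor, a higher number a weaker inhibitor), compound 3 gives the highest number of the three, 2650 nM, making it the weakest inhibitor so far. Compound 4 `Cc1cc(Nc2cc(N3CCN(C)CC3)nc(Nc3cccc(Cl)c3)n2)n[nH]1` carries chloro in place of methoxy on an aromatic carbon. Among the measured compounds shown here, no measured step makes this exact swap. The closest evidence is a 2.9-fold higher number from compound 1 to compound 3 (0.46 log units; beyond the scatter) and a 2.2-fold higher number from compound 2 to compound 3 (0.34 log units; beyond the scatter), both modest, and a 1.3-fold higher number from compound 1 to compound 2 (0.11 log units; within the scatter), within the scatter. Those steps exchanged larger pieces than this one, so no firm direction follows, and no change beyond the scatter is expected. The estimated step is a 1.3-fold lower number from compound 3 to compound 4 (0.12 log units; within the scatter). For compound 4 the estimated value is 2000 nM, with an expected range of 800 nM to 5000 nM.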

Compound 4, half-maximal inhibitory concentration: 3090 nM
Beside the measured number, compound 4's estimate is 1.5-fold (0.19 log units) below it, and the stated range covers the measured number.
By their numbers in this assay, from the lowest: compounds 1 and 2 (each within the scatter of the next); then compounds 3 and 4 (each within the scatter of the next).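

Chloro and methoxy on this carbon cannot be told apart in this assay (a 1.2-fold higher number from compound 3 to compound 4 (0.07 log units; within the scatter)), so this swap of a two-atom group for a one-atom group leaves the result within the scatter. The 3-chlorophenyl compound also falls on the weaker side of the two compounds with other aryl groups, and both gaps are modest (a 2.6-fold higher number from compound 2 to compound 4 (0.41 log units; beyond the scatter); a 3.3-fold higher number from compound 1 to compound 4 (0.52 log units; beyond the scatter)). Nothing measured here offers a reason for these numbers.

Still open, as far as these compounds go, is whether an amine or a carboxylic acid on this carbon would give a clearly different number. The compounds shown also do not tell whether a longer chain would be tolerated there.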